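Changing the Aryl Group on the Amide-Type Nitrogen

A few compounds are considered here, and "the series" means these few. Any claim that something is new, unique, unknown or untested is made for them only; others in the source may bear on it.

Three compounds share one core and differ only in the aromatic ring that hangs on an amide-type nitrogen. Compound 1 `CC(C)[C@@H]1CC[C@@H](C)C[C@@]12N(C)C(=O)[C@@H]1[C@H]3C(=O)N(c4ccccc4)C(=O)[C@H]3ON12` carries an unsubstituted phenyl group; in a functional assay, read by spectrophotometry, with a stated time of 2 h, tested at 2 mg/mL (on this read-out lower numbers stand for a weaker effect and higher numbers for a stronger effect at the one concentration tested), compound 1 gives 48.2%. Compound 2 `CC(C)[C@@H]1CC[C@@H](C)C[C@@]12N(C)C(=O)[C@@H]1[C@H]3C(=O)N(c4ccc(Cl)cc4)C(=O)[C@H]3ON12` carries a chloro substituent on that ring, and in this assay compound 2 gives 56.4%. Compound 3 `COc1ccc(N2C(=O)[C@H]3[C@H](ON4[C@@H]3C(=O)N(C)[C@@]43C[C@H](C)CC[C@H]3C(C)C)C2=O)cc1` carries a methoxy substituent instead, and in this assay compound 3 gives 55.7%. Compound 3 thus has the second highest of the three numbers, yet all three lie within the usual scatter of one another: a number 7.5 percentage points higher from compound 1 to compound 3 (within the scatter), a number 8.2 percentage points higher from compound 1 to compound 2 (within the scatter) and a number 0.7 percentage points lower from compound 2 to compound 3 (within the scatter).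

Compound 4 `Cc1cccc(N2C(=O)[C@H]3[C@H](ON4[C@@H]3C(=O)N(C)[C@@]43C[C@H](C)CC[C@H]3C(C)C)C2=O)c1` is the next step: 3-methylphenyl in place of 4-methoxyphenyl on an amide-type nitrogen in a ring. Among the compounds with values here, no measured step tests a methyl group on this ring, so the only guide is that every change made on this ring so far, whether chloro, methoxy or the swap between them, stayed within the scatter. The expected step for compound 4 is a number 2.7 percentage points lower from compound 3 to compound 4 (within the scatter), no larger than the scatter. In this assay compound 4 is estimated at 53%, within a range from 42% to 64%.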

Compound 4, a percentage reported as activity, at one concentration (the size of the read-out at that concentration, not a potency): 43.6%
Beside the measured number, compound 4's estimate is 9.4 percentage points above it; the measured number falls inside the stated range.
By their numbers in this assay, from the lowest: compounds 4, 1, 3 and 2 (each within the scatter of the next, the first and the last beyond it).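

Within the data shown here, the step to 3-methylphenyl is the first change on this ring to go beyond the scatter in this assay: replacing 4-methoxyphenyl gives a number 12.1 percentage points lower from compound 3 to compound 4 (beyond the scatter) and replacing 4-chlorophenyl gives a number 12.8 percentage points lower from compound 2 to compound 4 (beyond the scatter), so this position is not as indifferent to change as the earlier compounds suggested. Against the unsubstituted phenyl group, however, adding the methyl group gives only a number 4.6 percentage points lower from compound 1 to compound 4 (within the scatter), which means that the separation appears against the two substituted rings and not against the plain ring. No measurement available here gives a reason for these steps.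

The compounds shown leave open whether the separation follows the change of group or the change in where the group sits on the ring, as 3-methylphenyl differs from the other two substituted rings in both respects. Also open, going by these compounds, is how an amine, a carboxylic acid or a longer chain on this ring would read in this assay and whether any such group would stand clear of the scatter relative to the plain phenyl ring of compound 1.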